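Replacing 5-bromo-2-hydroxyphenyl with 2-phenylethenyl in compound 3

The source may hold more compounds than are shown below. What is called first, only, known or untested is meant among the compounds shown, and "the series" means these compounds.

Measured in a functional assay on SW 1116 cells (Homo sapiens) for cytotoxicity, read by MTT assay, with a stated time of 48 h; a lower number here means a stronger inhibitor, a higher number a weaker inhibitor:
- compound 1 `Cc1ccc(/C=N/NC(=O)CSc2nnc(-c3ccncc3)o2)cc1`: 16800 nM
- compound 2 `O=C(CSc1nnc(-c2ccncc2)o1)N/N=C/c1ccccc1[N+](=O)[O-]`: 30700 nM
- compound 3 `O=C(CSc1nnc(-c2ccncc2)o1)N/N=C/c1cc(Br)ccc1O`: 8150 nM

The lowest of these three numbers belongs to compound 3, at 8150 nM. The data show a 2.1-fold lower number from compound 1 to compound 3 (0.31 log units; beyond the scatter) and a 3.8-fold lower number from compound 2 to compound 3 (0.58 log units; beyond the scatter), both modest. Compound 4 `O=C(CSc1nnc(-c2ccncc2)o1)N/N=C/C=C/c1ccccc1` carries 2-phenylethenyl in place of 5-bromo-2-hydroxyphenyl on a carbon with a double bond to nitrogen.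

For the measured compounds named here, no measured compound carries 2-phenylethenyl, so no step bears on this change directly. The nearest evidence is what happens without 5-bromo-2-hydroxyphenyl: the two aryl replacements sit close together, with a 1.8-fold higher number from compound 1 to compound 2 (0.26 log units; within the scatter), and both give higher numbers than compound 3. Compound 4 is therefore placed near them, though its new group is unlike either. The step expected in this assay is modest and towards a higher number, a 2.1-fold higher number from compound 3 to compound 4 (0.32 log units; beyond the scatter). Compound 4 is estimated at 17000 nM, with an expected range from 6000 nM to 45000 nM.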

Compound 4, half-maximal inhibitory concentration: 14900 nM
For compound 4 the middle estimate is 1.1-fold (0.06 log units) above the measured one, within the range that was stated.
By their numbers in this assay, from the lowest: compounds 3, 4, 1 and 2 (each within the scatter of the next, the first and the last beyond it).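

In this assay, exchanging 5-bromo-2-hydroxyphenyl for 2-phenylethenyl on the carbon with a double bond to nitrogen gives a 1.8-fold higher number from compound 3 to compound 4 (0.26 log units; within the scatter), so an all-carbon group with 0 hydrogen-bond donors and 0 hydrogen-bond acceptors stays within the scatter of compound 3 at this position. It also stays within the scatter of the 4-methylphenyl compound, with a 1.1-fold lower number from compound 1 to compound 4 (0.05 log units; within the scatter), whereas the 2-nitrophenyl compound is separated from it, with a 2.1-fold lower number from compound 2 to compound 4 (0.31 log units; beyond the scatter), which shows that a group with an extra double bond outside the aromatic ring is tolerated here. No measurement at hand gives a reason for these steps.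

From the compounds shown here alone, whether a saturated 2-phenylethyl chain, or an amine or a carboxylic acid on the phenyl ring of 2-phenylethenyl, would keep the number near that of compound 4 remains open. Going by these compounds, the separate contributions of the hydroxyl and the bromine in compound 3 also remain open.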